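Side chain change on compound 2

The compounds below may be only part of what the source reports. "The series", "measured", "known", "first", "only" and "open" are said of these compounds alone.

Measured in a functional assay on HCT-8 cells (Homo sapiens) for antiproliferative activity, read by MTT assay, with a stated time of 48 h; a lower number here means a stronger inhibitor, a higher number a weaker inhibitor:
- Compound 1 `CCNCC(=O)Nc1cc(OC)ccc1C(=O)c1ccc(OC)c2c1OC(C)(C)C=C2`: 3690 nM
- Compound 2 `C=C(c1cc(OC)c(OC)c(OC)c1)c1ccc(OC)cc1NC(=O)CO`: 40 nM

Compound 2 holds the lower of the two numbers, beyond the scatter from compound 1. Compound 3 `C=C(c1cc(OC)c(OC)c(OC)c1)c1ccc(OC)cc1NC(=O)CNCC` carries ethylamino in place of hydroxy on a saturated chain carbon bound to a carbonyl carbon. Among the measured compounds shown here, no measured pair isolates this change. Compound 1, with its different core, also bears ethylamino and gives 3690 nM, so a higher number is expected in this assay, though not one that high. The estimated step is a 3.8-fold higher number from compound 2 to compound 3 (0.57 log units; beyond the scatter). For compound 3 the estimated value is 150 nM, with an expected range from 30 nM to 800 nM.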

Compound 3, half-maximal inhibitory concentration: 590 nM
For compound 3 the middle estimate is 3.9-fold (0.59 log units) below the measured one; the range from low to high includes it.
By their numbers in this assay, from the lowest: compound 2; then compound 3; then compound 1.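

In this assay, among the compounds shown here, on the shared core, ethylamino in place of hydroxy on a saturated chain carbon bound to a carbonyl carbon gives a 15-fold higher number from compound 2 to compound 3 (1.17 log units; beyond the scatter), the first reading of a single change at this position. The step is large, so the position is sensitive to this change, even though hydroxy and ethylamino show the same hydrogen-bond donor and acceptor counts. Nothing available here accounts for the size of this step.

As far as these compounds go, whether an unsubstituted amine, a methoxy group or a longer chain on this carbon stays closer to compound 2 remains open. So does the outcome with a carboxylic acid at this position.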